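Fluoro to methoxy on the bromo compound

A few compounds are considered here, and "the series" means these few. Any claim that something is new, unique, unknown or untested is made for them only; others in the source may bear on it.

In a functional assay on A549 cells (Homo sapiens) for antiproliferative activity, read by MTT assay, with a stated time of 48 h (on this read-out higher numbers stand for weaker inhibition and lower numbers for stronger inhibition), three compounds sharing one core have been measured so far. Compound 1 `Fc1ccc(-c2nn(-c3ccccc3)cc2-c2nc3cc(Cl)ccc3[nH]2)cc1`, which carries chloro, gives 1320 nM. Compound 2 `Fc1ccc(-c2nn(-c3ccccc3)cc2-c2nc3cc(Br)ccc3[nH]2)cc1`, with bromo in that place, gives 5830 nM. Compound 3 `O=C(OCc1ccccc1)c1ccc2[nH]c(-c3cn(-c4ccccc4)nc3-c3ccc(F)cc3)nc2c1`, with benzyloxycarbonyl there, gives 21500 nM. Compound 2 thus sits in the middle, second highest of the three numbers.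

Compound 4 `COc1ccc(-c2nn(-c3ccccc3)cc2-c2nc3cc(Br)ccc3[nH]2)cc1` keeps the bromo of compound 2 but differs elsewhere: methoxy in place of fluoro on an aromatic carbon, para to a large group, turning 4-fluorophenyl into 4-methoxyphenyl (methoxy in place of fluoro on an aromatic carbon).

The measured steps bear on this only indirectly. Bromo in place of chloro gave a 4.4-fold higher number from compound 1 to compound 2 (0.65 log units; beyond the scatter), benzyloxycarbonyl in place of bromo gave a 3.7-fold higher number from compound 2 to compound 3 (0.57 log units; beyond the scatter), and benzyloxycarbonyl in place of chloro gave a 16-fold higher number from compound 1 to compound 3 (1.21 log units; beyond the scatter). All three change a different place from the one altered here, so none tests fluoro against methoxy. Within the data shown here, they show only that a single swap in this small set can move the number well beyond the scatter, and they offer no direction for this one. The estimated step is a 1.3-fold lower number from compound 2 to compound 4 (0.11 log units; within the scatter), which is not expected to stand clear of the scatter. For compound 4 the estimated value is 4500 nM, with an expected range from 1300 nM to 15000 nM.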

Compound 4, half-maximal inhibitory concentration: 6370 nM
Compound 4: middle estimate off by 1.4-fold (0.15 log units), on the low side; the range from low to high includes it.
By their numbers in this assay, from the lowest: compound 1; then compounds 2 and 4 (each within the scatter of the next); then compound 3.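

In this assay the step of methoxy in place of fluoro is a 1.1-fold higher number from compound 2 to compound 4 (0.04 log units; within the scatter) and lies within the scatter, so compound 2 and compound 4 cannot be told apart on this read-out. The earlier steps shown here all changed the other place on the shared core and all lay beyond the scatter, whereas this first look at the 4-fluorophenyl ring shows that, with bromo held fixed, going to 4-methoxyphenyl gives no measurable difference, even though the entering group is larger by one heavy atom and brings a hydrogen-bond acceptor that fluoro, as counted here, does not. No measurement is available to explain this result.

One open question is whether the same swap would also leave the number within the scatter with chloro or benzyloxycarbonyl in the place that bromo holds, since a single pair cannot show this. The compounds shown also leave open how other groups on this ring would compare with fluoro and methoxy, such as an amine, a carboxylic acid or a longer chain like butoxy.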